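Ethoxycarbonyl to methoxycarbonyl on the shared core

The compounds below may be only part of what the source reports. "The series", "measured", "known", "first", "only" and "open" are said of these compounds alone.

In a functional assay on HL-60 cells (Homo sapiens) for cytotoxicity, read by MTT assay, with a stated time of 72 h (on this read-out higher numbers stand for weaker inhibition and lower numbers for stronger inhibition), compound 1 `COC(=O)c1sc2cc(OC)ccc2c1Nc1cc(OC)c(OC)c(OC)c1` gives 0.4 nM and compound 2 `CCOC(=O)c1sc2ccccc2c1Nc1cc(OC)c(OC)c(OC)c1` gives 5490 nM as the higher of the two numbers, far beyond the scatter. Compound 3 `COC(=O)c1sc2ccccc2c1Nc1cc(OC)c(OC)c(OC)c1` differs from compound 2 by hydrogen in place of methyl on a saturated chain carbon bound to an oxygen next to a carbonyl group with hydrogen in place of methyl on a saturated chain carbon bound to an oxygen next to a carbonyl group, so ethoxycarbonyl becomes methoxycarbonyl. No measured pair sizes this change. A modest fall in the number is expected in this assay for the step of a 2.7-fold lower number from compound 2 to compound 3 (0.44 log units; beyond the scatter) and no more than that. Compound 3 is expected at 2000 nM with 200 nM to 10000 nM as the estimated range.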

Compound 3, half-maximal inhibitory concentration: 1540 nM
For compound 3 the middle estimate is 1.3-fold (0.11 log units) above the measured one; the range from low to high includes it.
By their numbers in this assay, from the lowest: compound 1; then compound 3; then compound 2.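

The ester chain now has a measured size in this assay: ethoxycarbonyl to methoxycarbonyl gives a 3.6-fold lower number from compound 2 to compound 3 (0.55 log units; beyond the scatter) and stays a modest change. For the compounds shown here, compound 3 also gives the first single-place reading for the methoxy: hydrogen in place of methoxy on an aromatic carbon gives a 3900-fold higher number from compound 1 to compound 3 (3.59 log units; beyond the scatter) as a large step, far outweighing the ester change.

On these data alone, how a longer chain such as propyl, or a carboxylic acid or amide in place of the ester, would read stays open, as does the ethoxycarbonyl change with that methoxy present. Nothing available here accounts for either step.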